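Aryl Swap on the Pyrimidine Amine: Compound 2 to Compound 3

The source may hold more compounds than are shown below. What is called first, only, known or untested is meant among the compounds shown, and "the series" means these compounds.

Measured compounds:
Compound 1 `Cc1[nH]c2ccccc2c1-c1ccnc(NC(CO)C(C)C)n1`: 50000 nM
Compound 2 `Cc1[nH]c2ccccc2c1-c1ccnc(Nc2cccnc2)n1`: 100 nM

In an assay on isolated protein for inhibition of interferon-induced, double-stranded RNA-activated protein kinase (Homo sapiens), read by luminescence, with a stated time of 10 min (a higher number here means a weaker inhibitor, a lower number a stronger inhibitor), compound 1 gives 50000 nM, while compound 2 gives 100 nM. Within the data shown here, the single measured step, a 500-fold lower number from compound 1 to compound 2 (2.70 log units; beyond the scatter), shows that what sits on the nitrogen on the aromatic ring matters greatly. Compound 2 therefore stands with the lowest number of the two measured compounds, with compound 1 far behind it.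

Compound 3 `Cc1[nH]c2ccccc2c1-c1ccnc(Nc2cccc(Cl)c2)n1` has not yet been measured. It differs from compound 2 by 3-chlorophenyl in place of pyridin-3-yl on a nitrogen on an aromatic ring. Among the measured compounds shown here, the one measured step does not bear directly on this change, since it replaces a branched alcohol-bearing chain with an aromatic ring rather than exchanging one aromatic ring for another. For the measured compounds named here, no measured pair tells what swapping a pyridine for a chlorinated benzene does here. Going by the values given here, one can only say that both aromatic groups sit in the same place, so an enormous shift like the one from compound 1 is not expected.

Compound 3 is estimated at 300 nM, within 60 nM to 3000 nM, meaning an expected step of a 3.0-fold higher number from compound 2 to compound 3 (0.48 log units; beyond the scatter), a modest weakening with wide uncertainty.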

Compound 3, half-maximal inhibitory concentration: 300 nM
Compound 3: middle estimate and measured number agree at the digits printed, within the range that was stated.
By their numbers in this assay, from the lowest: compound 2; then compound 3; then compound 1.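

In this assay, putting one aromatic ring in place of another on the nitrogen has a measurable but much smaller effect than replacing the chain, with a 3.0-fold higher number from compound 2 to compound 3 (0.48 log units; beyond the scatter), so the identity of the aromatic group still matters and pyridin-3-yl gives the lower number of the two. The large gain over the 1-(hydroxymethyl)-2-methylpropyl group does not depend on a ring nitrogen, as 3-chlorophenyl, whose ring is carbon only, still gives a 170-fold lower number from compound 1 to compound 3 (2.22 log units; beyond the scatter), and both aromatic compounds therefore stand far below compound 1. Nothing available explains why either step has the size it does.

The exchange from compound 2 to compound 3 removes the ring nitrogen and adds chlorine in a single step, so the share of each in the modest rise cannot be separated. A plain phenyl group would divide that step into its two parts, while an amine or a carboxylic acid on the ring in place of chlorine would show how far this position tolerates other substituents.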